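Piperazine dithiocarbamate benzamides: swapping the ring-nitrogen substituent

This account rests on a few compounds, and the source may have more. Where it says the series, first, only, none or still open, it means among the compounds named here.

Measured compounds:
compound 1 `Nc1ccccc1NC(=O)c1ccc(CSC(=S)N2CCN(Cc3ccccn3)CC2)cc1`: 65.2%
compound 2 `CCN(Cc1ccncc1)C(=S)SCc1ccc(C(=O)Nc2ccccc2N)cc1`: 85.2%

In a functional assay on MGC-803 cells (Homo sapiens) for antiproliferative activity, read by CCK-8 assay, with a stated time of 72 h, tested at 8 uM (on this read-out higher numbers stand for a stronger effect at the one concentration tested and lower numbers for a weaker effect), compound 1 gives 65.2%, the lower of the two numbers. Compound 2, built on a different amine, gives 85.2% in this assay, a gap beyond the scatter. Compound 3 `COc1ccc(N2CCN(C(=S)SCc3ccc(C(=O)Nc4ccccc4N)cc3)CC2)cc1` is not yet measured. It differs from compound 1 in one place (4-methoxyphenyl in place of (pyridin-2-yl)methyl on an amine nitrogen in a ring). Within the data shown here, no measured pair shows this change, so its effect is unknown. A modest step from compound 1 to compound 3 is expected, a number 4.8 percentage points higher from compound 1 to compound 3 (within the scatter), not clearly beyond the scatter. Compound 3 is thus estimated at 70% in this assay, within 50% to 88%.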

Compound 3, a percentage reported as inhibition, at one concentration (the size of the read-out at that concentration, not a potency): 22.9%
Compound 3: the middle estimate sits 47.1 percentage points above what was measured; the measured number lies below the stated range.
By their numbers in this assay, from the lowest: compound 3; then compound 1; then compound 2.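

In this assay, 4-methoxyphenyl in place of (pyridin-2-yl)methyl on the amine nitrogen in the ring gives a number 42.3 percentage points lower from compound 1 to compound 3 (beyond the scatter). This position is therefore sensitive to the choice of substituent: exchanging one group bearing a six-membered aromatic ring for another does not preserve the read-out. No available data explain the size of this step.

Going by these compounds, it remains open whether the drop follows the methoxy group, the carbon-only ring or the direct attachment of that ring to the nitrogen. Benzyl and 4-methoxybenzyl groups at this position would separate these possibilities.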